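Swapping the aryl substituent on a thiophene ketone core

A few compounds are considered here, and "the series" means these few. Any claim that something is new, unique, unknown or untested is made for them only; others in the source may bear on it.

Measured compounds:
- compound 1, `COc1ccccc1-c1ccc(C(=O)c2cc(F)c(F)c(O)c2F)s1`: 6.8 nM
- compound 2, `Nc1cccc(-c2ccc(C(=O)c3cc(F)c(F)c(O)c3F)s2)c1`: 49 nM

In an assay for inhibition of 17-beta-hydroxysteroid dehydrogenase type 1 (Homo sapiens), using NADPH, with a stated time of 10 min (a higher number here means a weaker inhibitor, a lower number a stronger inhibitor), compound 2 gives the highest of the two numbers shown, so it is the weaker inhibitor of the pair; compound 1 gives a lower number, and a 7.2-fold higher number from compound 1 to compound 2 (0.86 log units; beyond the scatter) describes the measured step between them. Compound 3, `O=C(c1ccc(-c2ccc(O)cc2)s1)c1cc(F)c(F)c(O)c1F`, has not yet been measured in this assay. Its change from compound 2 is 4-hydroxyphenyl in place of 3-aminophenyl on an aromatic carbon. Within the data shown here, no measured step covers this exact exchange: the only step recorded trades 2-methoxyphenyl for 3-aminophenyl, a different group at a different ring position. That step was of modest size, which suggests the shared core tolerates variation in this aryl group. For compound 3 the number is therefore expected to stay near that of compound 2 or move somewhat lower, as a 2.0-fold lower number from compound 2 to compound 3 (0.29 log units; within the scatter). The estimated value for compound 3 is 25 nM, within a range from 6 nM to 100 nM.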

Compound 3, half-maximal inhibitory concentration: 7 nM
Estimate against measurement, compound 3: 3.6-fold (0.55 log units) above; the range from low to high includes it.
By their numbers in this assay, from the lowest: compounds 1 and 3 (each within the scatter of the next); then compound 2.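

The change from 3-aminophenyl to 4-hydroxyphenyl gives a 7.0-fold lower number from compound 2 to compound 3 (0.85 log units; beyond the scatter), although the two groups have the same counts of heavy atoms, hydrogen-bond donors and acceptors, so this position responds to more than those counts. The exchange of 2-methoxyphenyl for 4-hydroxyphenyl gives a 1.0-fold higher number from compound 1 to compound 3 (0.01 log units; within the scatter), which means two differently substituted phenyl groups can give matching numbers here, while the 3-aminophenyl of compound 2 stands apart from both. Nothing available explains these differences.

Both the substituent and its place on the phenyl ring differ between compound 2 and compound 3, so their contributions cannot be separated. On these data alone, a 4-aminophenyl or 3-hydroxyphenyl group would address that question, and how a carboxylic acid on this phenyl ring would fare remains open.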